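Lengthening the Acyl Chain on a Weak Inhibitor

This account rests on a few compounds, and the source may have more. Where it says the series, first, only, none or still open, it means among the compounds named here.

The shared core is seen in compound 1 `O=C(Nc1ccccc1)C1CCc2ccccc2N1`, which in a functional assay on NCI-H23 cells (Homo sapiens) for cytotoxicity, read by sulforhodamine B assay, with a stated time of 72 h (a lower number here means a stronger inhibitor of growth, a higher number a weaker inhibitor of growth), gives 97100 nM. Compound 3 `O=C(Nc1ccccc1C(F)(F)F)C1CCc2ccccc2N1C(=O)c1ccccc1Cl` gives 2150 nM in this assay. Compound 2 `CC(=O)N1c2ccccc2CCC1C(=O)Nc1cc(C(F)(F)F)cc(C(F)(F)F)c1` returns only a limit in this assay, namely > 70000 nM. That figure is the assay limit (the limit of > 70000 nM in this assay, at which 1 of the 3 values shown sits), not a measured number, so compound 2 cannot be ranked against the other two. Compound 4 `CCCC(=O)N1c2ccccc2CCC1C(=O)Nc1cc(C(F)(F)F)cc(C(F)(F)F)c1` differs from compound 2 by ethyl in place of hydrogen on a saturated chain carbon bound to a carbonyl carbon. Within the data shown here, no measured pair covers this change, so the size of the step is open; a modest gain is expected, not clearly beyond the scatter, with a real chance of a second limit. The step of an at least 1.1-fold lower number from compound 2 to compound 4 (0.06 log units; that floor lies within the scatter) is the estimate that follows. Compound 4 is thus expected near 60000 nM, between 20000 nM and 200000 nM.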

Compound 4, concentration for 50% growth inhibition: 15000 nM
For compound 4 the middle estimate is 4.0-fold (0.60 log units) above the measured one; the measured number lies below the stated range.
By their numbers in this assay, from the lowest: compound 3; then compound 4; then compound 1.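

Ethyl in place of hydrogen on a saturated chain carbon bound to a carbonyl carbon gives a change beyond the scatter in this assay (an at least 4.6-fold lower number from compound 2 to compound 4 (0.66 log units; beyond the scatter)). Among these compounds, this is the first step at this position that can be read, and compound 4 carries a measured number where compound 2 does not. The true size of the step stays open, since compound 2 holds only a limit, which makes the step a floor: the limit of > 70000 nM in this assay, at which 1 of the 4 values shown sits.

Going by these compounds, whether a longer chain, or an amine in place of the ethyl, would lower the number further remains open. So does whether ethyl would give a like step on the core of compound 1.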